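The source may hold more compounds than are shown below. What is called first, only, known or untested is meant among the compounds shown, and "the series" means these compounds.

Measured compounds:
Compound 1 `C=C(C)C(=O)c1ccc(OCc2nc(-c3ccc([N+](=O)[O-])cc3)no2)c(C)c1C` gives 2300 nM in an assay on HL-60 cells for inhibition of glutathione S-transferase P (Homo sapiens); a higher number here means a weaker inhibitor, a lower number a stronger inhibitor.
Compound 2 `C=C(CC)C(=O)c1ccc(OCc2nc(C)no2)c(Cl)c1Cl` gives 4000 nM in this assay.

Compound 2 has the higher of the two numbers, but compound 1 lies within the scatter of it, so no order between the two can be claimed. Compound 3 `C=C(CC)C(=O)c1ccc(OCc2nc(-c3ccccc3)no2)c(Cl)c1Cl` differs from compound 2 by phenyl in place of methyl on an aromatic carbon. Going by the values given here, no measured pair isolates this change, and compound 1 differs from compound 2 in more than one place, so its value is only a loose hint. Compound 3 is expected to show a small step, a 1.6-fold lower number from compound 2 to compound 3 (0.20 log units; within the scatter), toward a lower number, likely within the scatter. Compound 3 is estimated at 2500 nM, with a range from 1000 nM to 6000 nM.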

Compound 3, half-maximal inhibitory concentration: 3600 nM
The estimate for compound 3 lay 1.4-fold (0.16 log units) below the measured number; the measured number falls inside the stated range.
By their numbers in this assay, from the lowest: compounds 1, 3 and 2 (each within the scatter of the next).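

Phenyl in place of methyl on this aromatic carbon, between two ring nitrogen atoms, gives a 1.1-fold lower number from compound 2 to compound 3 (0.05 log units; within the scatter) in this assay and thus no change that can be told from the scatter. The position therefore accepts an added six-membered aromatic ring of carbon only without a readable shift in this assay's number. Nothing available explains this result. The compounds shown leave open whether an amine, a carboxylic acid or a longer chain on this carbon would move the number beyond the scatter. They also leave open what a nitro group on the phenyl does on its own.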